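Swapping isopropyl for phenyl on a side chain

The source may hold more compounds than are shown below. What is called first, only, known or untested is meant among the compounds shown, and "the series" means these compounds.

Measured in a functional assay on HeLa cells (Homo sapiens) for antiproliferative activity, read by MTT assay, with a stated time of 72 h; a higher number here means a weaker inhibitor, a lower number a stronger inhibitor:
Compound 1 `C/C=C1/[C@H](O[C@@H]2O[C@H](CO)[C@@H](O)[C@H](O)[C@H]2O)OC=C(C(=O)OC)[C@H]1CC(=O)OCCc1ccc(O)c(O)c1`: 265000 nM
Compound 2 `C/C=C1/[C@H](O[C@@H]2O[C@H](CO)[C@@H](O)[C@H](O)[C@H]2O)OC=C(C(=O)OC)[C@H]1CC(=O)OCCC(C)C`: 19500 nM

Of these two numbers, compound 2 has the lower, 19500 nM, which makes it the stronger inhibitor of the pair in this assay. Compound 3 `C/C=C1/[C@H](O[C@@H]2O[C@H](CO)[C@@H](O)[C@H](O)[C@H]2O)OC=C(C(=O)OC)[C@H]1CC(=O)OCCc1ccccc1` carries phenyl in place of isopropyl on a saturated chain carbon, two bonds along the chain from an oxygen next to a carbonyl group. Within the data shown here, one measured step bears on this place: a 14-fold lower number from compound 1 to compound 2 (1.13 log units; beyond the scatter), a large change that came with isopropyl replacing 3,4-dihydroxyphenyl. Among the measured compounds shown here, compound 3 has a ring there, as compound 1 does, but no measured compound carries plain phenyl. Only part of that large step is therefore expected to reverse. The expected change is modest, an estimated 1.9-fold higher number from compound 2 to compound 3 (0.29 log units; within the scatter), towards a higher number. For compound 3 the estimated value is 38000 nM, with an expected range from 12000 nM to 120000 nM.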

Compound 3, half-maximal inhibitory concentration: 18500 nM
The estimate for compound 3 lay 2.1-fold (0.31 log units) above the measured number; low and high end bracket the measured number.
By their numbers in this assay, from the lowest: compounds 3 and 2 (each within the scatter of the next); then compound 1.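

In this assay, a ring at this place does not by itself bring the number back up: the step of a 1.1-fold lower number from compound 2 to compound 3 (0.02 log units; within the scatter) lies within the scatter, so phenyl and isopropyl cannot be told apart here. The step of a 14-fold lower number from compound 1 to compound 3 (1.16 log units; beyond the scatter) is large, as was the step from compound 1 to compound 2, so the high number of compound 1 goes with 3,4-dihydroxyphenyl specifically, not with having a ring on the chain. Nothing measured here explains why the two hydroxyl groups on that ring go with a weaker result.

From the compounds shown here alone, it remains open whether a single hydroxyl on the phenyl ring would give a number closer to compound 1 or to compound 3. Going by these compounds, how an amine, a carboxylic acid or a longer chain would read at this place is also open.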